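Working notes: cytotoxicity of two isomeric glycosides and an acid

The source may report more compounds than this note shows. Statements on the series, on what has been measured and on what is new or still open speak of the compounds shown alone.

compound 1 `C[C@@H]1C[C@H](O)[C@@]2(C)C(C=O)=CCC[C@@H]2[C@@]1(C)CC(=O)O`: 713000 nM
compound 2 `C=C[C@](C)(O)CC[C@@]1(C)[C@H](C)C[C@H](O[C@@H]2O[C@@H](C)[C@H](O[C@@H]3O[C@H](COC(C)=O)[C@@H](O)[C@H](O)[C@H]3O)[C@@H](O)[C@H]2O)[C@@]2(C)C(C)=CCC[C@H]12`: 121000 nM

In an ADME assay on C8166 cells (Homo sapiens) for cytotoxicity, read by MTT assay (a higher number here means that more compound is tolerated, a lower number that less compound is tolerated), compound 1 gives 713000 nM. Compound 2 gives 121000 nM in this assay, the lowest of the two numbers; compound 1 stands higher by a gap beyond the scatter. Compound 3 `CC(=O)OC[C@H]1O[C@@H](O[C@@H]2[C@@H](O)[C@@H](O)[C@H](O[C@H]3C[C@@H](C)[C@](C)(CC/C(C)=C/CO)[C@H]4CCC=C(C)[C@]34C)O[C@H]2C)[C@H](O)[C@@H](O)[C@@H]1O` differs from compound 2 by 3-hydroxy-1-methylprop-1-en-1-yl in place of 1-hydroxy-1-methylprop-2-en-1-yl on a saturated chain carbon, two bonds along the chain from a saturated ring carbon. The two have the same atoms joined differently. Among the compounds with values here, no measured pair shows this change. The expected step of a 1.1-fold higher number from compound 2 to compound 3 (0.03 log units; within the scatter) is none beyond the scatter. Compound 3 is estimated at 130000 nM, with a range from 50000 nM to 350000 nM.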

Compound 3, half-maximal cytotoxic concentration: 136000 nM
For compound 3 the middle estimate is 1.0-fold (0.02 log units) below the measured one; the measured number falls inside the stated range.
By their numbers in this assay, from the lowest: compounds 2 and 3 (each within the scatter of the next); then compound 1.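

The exchange of 1-hydroxy-1-methylprop-2-en-1-yl for 3-hydroxy-1-methylprop-1-en-1-yl on a saturated chain carbon, two bonds along the chain from a saturated ring carbon, gives a 1.1-fold higher number from compound 2 to compound 3 (0.05 log units; within the scatter) in this assay. This first single-place comparison in the series shows that, at this position and in this assay, these two isomeric groups cannot be told apart. No measurement at hand accounts for this result.

Open, going by these compounds, is whether a carboxylic acid, an amine or a longer chain at this position would stay within the scatter of compound 2. The compounds shown also leave open whether this exchange would read the same on another core.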